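Swapping 2-phenylethenyl for isobutoxy on a carbonyl carbon

The source may report more compounds than this note shows. Statements on the series, on what has been measured and on what is new or still open speak of the compounds shown alone.

Of the compounds shown here, three have been measured in a functional assay on HOP-62 cells (Homo sapiens) for antiproliferative activity; on this read-out higher numbers stand for weaker inhibition and lower numbers for stronger inhibition. Compound 2 `O=C(/C=C/c1ccccc1)N[C@@H](CCCCCC(=O)NO)C(=O)Nc1cccc2cccnc12` gives 65 nM, the lowest number of the three and so the strongest inhibition among them. Compound 3 `O=C(CCCCC[C@H](NC(=O)OCc1ccccc1)C(=O)Nc1cccc2cccnc12)NO` gives 226 nM, and compound 1 `O=C(CCCCC[C@H](NC(=O)c1ccc(Br)cc1)C(=O)Nc1ccc(-c2ccccc2)cc1)NO` gives 261 nM. Going by the values given here, both of these numbers lie clearly higher than the one for compound 2. Compound 1 differs from compound 2 in more than one place, so it offers no clean comparison.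

The next compound, compound 4 `CC(C)COC(=O)N[C@@H](CCCCCC(=O)NO)C(=O)Nc1cccc2cccnc12`, carries isobutoxy in place of 2-phenylethenyl on a carbonyl carbon. Among the compounds with values here, one measured step bears on this change. Putting benzyloxy in place of 2-phenylethenyl at that same kind of carbonyl carbon gave a 3.5-fold higher number from compound 2 to compound 3 (0.54 log units; beyond the scatter), a modest change beyond the scatter. Isobutoxy and benzyloxy are both joined to the carbonyl carbon through oxygen, but isobutoxy has no ring, and no measured compound tests what that difference does. On the evidence of compound 3 at 226 nM, a step of similar size is expected in this assay, towards a higher number and so weaker inhibition. The estimated step is a 3.4-fold higher number from compound 2 to compound 4 (0.53 log units; beyond the scatter). For compound 4 the estimate is 220 nM, with an expected range from 90 nM to 520 nM.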

Compound 4, half-maximal inhibitory concentration: 267 nM
For compound 4 the middle estimate is 1.2-fold (0.08 log units) below the measured one, within the range that was stated.
By their numbers in this assay, from the lowest: compound 2; then compounds 3, 1 and 4 (each within the scatter of the next).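

In this assay, isobutoxy on this carbonyl carbon gives a 4.1-fold higher number from compound 2 to compound 4 (0.61 log units; beyond the scatter), a modest step towards weaker inhibition that lies beyond the scatter. So compound 3 is no longer the only compound in which a group joined through oxygen at this place gives a higher number than 2-phenylethenyl does. Isobutoxy has no ring, yet the comparison with the benzyloxy compound gives a 1.2-fold higher number from compound 3 to compound 4 (0.07 log units; within the scatter), which lies within the scatter, so in this pair, with isopropyl in place of phenyl, the ring makes no difference that this assay can resolve. No measurement here offers a reason for either step.

Isobutoxy and benzyloxy each differ from 2-phenylethenyl both in the oxygen atom joined to the carbonyl carbon and in lacking the double bond, so the compounds shown cannot separate these two differences. A 2-phenylethyl group on the same carbonyl carbon would keep the carbon link and the ring without the double bond, and a benzylamino group would put a nitrogen where benzyloxy has its oxygen, so each would test one of these differences more directly.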